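The compounds below may be only part of what the source reports. "The series", "measured", "known", "first", "only" and "open" are said of these compounds alone.

In a functional assay on MDA-MB-231 cells (Homo sapiens) for cytotoxicity, read by MTT assay, with a stated time of 48 h (on this read-out higher numbers stand for weaker inhibition and lower numbers for stronger inhibition), compound 3 `Nc1ccc(C(=O)/C=C/c2ccc3c(c2)B(O)OC3)cc1` gives 25800 nM, the highest of the three numbers recorded. Compound 2 `O=C(/C=C/c1ccc2c(c1)B(O)OC2)c1ccc(O)cc1` gives 25600 nM, which sits within the scatter of that figure, and compound 1 `O=C(/C=C/c1ccc2c(c1)B(O)OC2)c1ccc(Br)cc1` gives 9500 nM, a lower number. The step of a 2.7-fold higher number from compound 1 to compound 2 (0.43 log units; beyond the scatter) and the step of a 2.7-fold higher number from compound 1 to compound 3 (0.43 log units; beyond the scatter) place the hydroxy and amino compounds above the bromo compound, while the step of a 1.0-fold higher number from compound 2 to compound 3 (0.00 log units; within the scatter) shows no separation between those two. Compound 4 `O=C(/C=C/c1ccc2c(c1)B(O)OC2)c1ccccc1O` carries 2-hydroxyphenyl in place of 4-aminophenyl on a carbonyl carbon. Among the compounds with values here, only the step of a 1.0-fold higher number from compound 2 to compound 3 (0.00 log units; within the scatter) bears directly on this exchange of a hydroxy for an amino group, and that step stayed within the scatter; no measured pair shows a 2-hydroxyphenyl on the carbonyl carbon, so that part of the change is untested. On that footing, compound 4 is expected to show a step of a 1.2-fold lower number from compound 3 to compound 4 (0.07 log units; within the scatter) in this assay, nothing beyond the scatter. Compound 4 is accordingly estimated at 22000 nM, with a range from 7000 nM to 70000 nM.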

Compound 4, half-maximal inhibitory concentration: 16900 nM
The estimate for compound 4 lay 1.3-fold (0.11 log units) above the measured number; the measured number falls inside the stated range.
By their numbers in this assay, from the lowest: compounds 1, 4, 2 and 3 (each within the scatter of the next, the first and the last beyond it).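

In this assay, within the data shown here, moving the hydroxy group gives the first comparison at this position: 2-hydroxyphenyl in place of 4-hydroxyphenyl on the carbonyl carbon gives a 1.5-fold lower number from compound 2 to compound 4 (0.18 log units; within the scatter), so the two placements are not separated. The exchange for 4-aminophenyl gives a 1.5-fold lower number from compound 3 to compound 4 (0.18 log units; within the scatter), and the exchange for 4-bromophenyl gives a 1.8-fold higher number from compound 1 to compound 4 (0.25 log units; within the scatter), so 2-hydroxyphenyl lies within the scatter of all three groups, even though the bromo compound stands apart from the other two. Nothing available explains these numbers.

The compounds shown leave open whether a methoxy group, a chlorine or a carboxylic acid on this aromatic ring would fall with the bromo compound or with the hydroxy and amino compounds. They also leave open how far these small differences hold once the shared core itself is changed.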